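This account rests on a few compounds, and the source may have more. Where it says the series, first, only, none or still open, it means among the compounds named here.

Measured in a functional assay on DU-145 cells (Homo sapiens) for cytotoxicity, read by MTT assay, with a stated time of 24 h; on this read-out lower numbers stand for stronger inhibition and higher numbers for weaker inhibition:

- compound 1 `CCCCCCCCCCCC(=O)Nc1nnc(S[C@@H]2O[C@H](COC(C)=O)[C@H](OC(C)=O)[C@H](OC(C)=O)[C@H]2OC(C)=O)s1`: 16900 nM
- compound 2 `CCCCCCCCCCCCCCCCCC(=O)Nc1nnc(S[C@@H]2O[C@H](CO)[C@H](O)[C@H](O)[C@H]2O)s1`: "not active" (no number reported)

Among the compounds with values here, compound 1, at 16900 nM, holds the only number available in this assay, so it cannot be ranked against a second figure. The one other entry, compound 2, gives "not active" (no number reported) and no number.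

Compound 3 `CCCCCCCC/C=C\CCCCCCCC(=O)Nc1nnc(S[C@@H]2O[C@H](COC(C)=O)[C@H](OC(C)=O)[C@H](OC(C)=O)[C@H]2OC(C)=O)s1` has not yet been measured. Its change from compound 1 is dec-1-en-1-yl in place of butyl on a saturated chain carbon, seven bonds along the chain from a carbonyl carbon, on a saturated chain carbon, seven bonds along the chain from a carbonyl carbon.

Within the data shown here, no pair of measured compounds shows what such a chain change does, so the expectation rests on compound 1 alone, at 16900 nM. The estimated 1.2-fold higher number from compound 1 to compound 3 (0.07 log units; within the scatter) is expected to be slightly towards weaker inhibition and no larger than the usual scatter. The estimate for compound 3 is 20000 nM, with an expected range from 7000 nM to 60000 nM.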

Compound 3, half-maximal inhibitory concentration: 42000 nM
Compound 3: middle estimate off by 2.1-fold (0.32 log units), on the low side; low and high end bracket the measured number.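

In this assay, dec-1-en-1-yl in place of butyl on a saturated chain carbon, seven bonds along the chain from a carbonyl carbon, gives a 2.5-fold higher number from compound 1 to compound 3 (0.40 log units; beyond the scatter) and so moves towards weaker inhibition. Within the data shown here, this is the first sign that the read-out responds to a change at this position of the chain, and the step is modest, with compound 3 still giving a number. No measurement at hand offers a reason for this step.

The compounds shown leave open whether the added length or the double bond carries the step. As far as these compounds go, it also remains open how a fully saturated chain of the same length, or a chain ending in an amine or a carboxylic acid, would read in this assay at this position.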